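Removing a methoxy group from a pyrazoline growth inhibitor

The compounds below may be only part of what the source reports. "The series", "measured", "known", "first", "only" and "open" are said of these compounds alone.

Measured compounds:
compound 1 `O=C(C1COc2ccccc2O1)N1N=C(c2ccc(Br)cc2)CC1c1ccccc1` 6150 nM
compound 2 `COc1ccc(C2=NN(C(=O)c3ccc4c(c3)OCCO4)C(c3ccccc3)C2)cc1` 2370 nM
compound 3 `COc1ccc(C2CC(c3ccc(Br)cc3)=NN2C(=O)c2ccc3c(c2)OCCO3)cc1` 5680 nM

Of the compounds shown here, three sharing one core have been tested in a functional assay on WM 266-4 cells (Homo sapiens) for inhibition, read by MTT assay, with a stated time of 24 h; on this read-out lower numbers stand for stronger inhibition of growth and higher numbers for weaker inhibition of growth. Compound 3, with its 4-methoxyphenyl group, stands at the second highest number of the three. Its nearest neighbour is compound 1, whose number lies within the scatter of that of compound 3, so no order between these two can be read. Compound 2 gives the lowest number of the set, and the gap from compound 3 to compound 2 lies beyond the scatter.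

Compound 4 `O=C(c1ccc2c(c1)OCCO2)N1N=C(c2ccc(Br)cc2)CC1c1ccccc1` has not yet been measured. It differs from compound 3 in one place: hydrogen in place of methoxy on an aromatic carbon. Going by the values given here, the change is small, and no measured pair in this set isolates it, so the expectation for its effect can rest only on the spread seen so far.

With this in mind, the step from compound 3 to compound 4 in this assay is expected to be modest, a 1.1-fold lower number from compound 3 to compound 4 (0.06 log units; within the scatter), in no direction that clearly exceeds the scatter. Compound 4 is therefore estimated to give 5000 nM in this assay, within a range from 2000 nM to 14000 nM, and the number is awaited.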

Compound 4, concentration for 50% growth inhibition: 1790 nM
Compound 4: middle estimate off by 2.8-fold (0.45 log units), on the high side; the whole stated range lies above it.
By their numbers in this assay, from the lowest: compounds 4 and 2 (each within the scatter of the next); then compounds 3 and 1 (each within the scatter of the next).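

In this assay, going by these compounds alone, a 3.2-fold lower number from compound 3 to compound 4 (0.50 log units; beyond the scatter) gives the first reading of this change, hydrogen in place of methoxy on an aromatic carbon, para to a large group; the step lies beyond the scatter, so on this scaffold the place is not silent, and the 4-methoxyphenyl to phenyl change goes with stronger inhibition of growth. The other aryl position can now be read as well: a 1.3-fold lower number from compound 2 to compound 4 (0.12 log units; within the scatter), with bromo in place of methoxy on an aromatic carbon, lies within the scatter, so compound 2 and compound 4 cannot be put in order. The acyl group also counts, since a 3.4-fold lower number from compound 1 to compound 4 (0.54 log units; beyond the scatter), with 2,3-dihydro-1,4-benzodioxin-6-yl in place of 2,3-dihydro-1,4-benzodioxin-2-yl on a carbonyl carbon, lies beyond the scatter.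

The compounds shown leave open whether a hydroxy group, a fluorine atom or a dimethylamino group at the para place would match hydrogen or methoxy, and whether the methoxy step would keep its size in another member of the series. Nothing given here accounts for the size of any of these steps.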